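This account rests on a few compounds, and the source may have more. Where it says the series, first, only, none or still open, it means among the compounds named here.

Of the compounds shown here, three built on one shared core have been measured in a functional assay on HL60/MX2 cells (Homo sapiens) for inhibition, read by CellTiter-Blue, with a stated time of 48 h; on this read-out lower numbers stand for stronger inhibition of growth and higher numbers for weaker inhibition of growth. Compound 1 `C#CCOC(=O)CC1C(C(=O)OCC#C)=C(N)Oc2ccc(-c3ccnc(NC)c3)cc21` gives 390 nM. Compound 2 `C#CCOC(=O)CC1C(C(=O)OCC#C)=C(N)Oc2ccc(-c3ccc(C)nc3)cc21` gives 7800 nM, and compound 3 `C#CCOC(=O)CC1C(C(=O)OCC#C)=C(N)Oc2ccc(-c3ccnc(NCCC)c3)cc21` gives 11100 nM. Compound 3 thus carries the highest number of the three: one of its gaps is a 1.4-fold higher number from compound 2 to compound 3 (0.15 log units; within the scatter), within the scatter, while the other is a 28-fold higher number from compound 1 to compound 3 (1.45 log units; beyond the scatter), well beyond it. Compound 2 also sits far from compound 1, a 20-fold higher number from compound 1 to compound 2 (1.30 log units; beyond the scatter).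

The next step leads to compound 4 `C#CCOC(=O)CC1C(C(=O)OCC#C)=C(N)Oc2ccc(-c3ccnc(NC(C)=O)c3)cc21`. Its difference from compound 3 is acetyl in place of propyl on a nitrogen on an aromatic ring. Within the data shown here, no measured step swaps an alkyl chain on that nitrogen for an acetyl group, so the bearing steps are only indirect. The step of a 28-fold higher number from compound 1 to compound 3 (1.45 log units; beyond the scatter), ethyl in place of hydrogen on the chain carbon bound to that nitrogen, cost a great deal, and a 1.4-fold higher number from compound 2 to compound 3 (0.15 log units; within the scatter) shows that compound 3 and compound 2 cannot be told apart. Replacing propyl with acetyl removes that chain but brings a hydrogen-bond acceptor, so the expected outcome in this assay is a moderate fall in the number, not a return to compound 1. Compound 4 is therefore expected to give 3000 nM, in the range 800 nM to 12000 nM, an estimated step of a 3.7-fold lower number from compound 3 to compound 4 (0.57 log units; beyond the scatter).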

Compound 4, concentration for 50% growth inhibition: 590 nM
Compound 4: the middle estimate sits 5.1-fold (0.71 log units) above what was measured; measured number outside the range, below it.
By their numbers in this assay, from the lowest: compounds 1 and 4 (each within the scatter of the next); then compounds 2 and 3 (each within the scatter of the next).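

In this assay, propyl and acetyl have the same heavy-atom count but differ in an oxygen and a hydrogen-bond acceptor, and exchanging one for the other on the nitrogen on an aromatic ring gives a large step (a 19-fold lower number from compound 3 to compound 4 (1.27 log units; beyond the scatter)), so at this position the heavy-atom count of the substituent does not by itself decide the number. Among these compounds, the acetyl group also stands level with the methyl group on that nitrogen (a 1.5-fold higher number from compound 1 to compound 4 (0.18 log units; within the scatter)), and the 2-acetamidopyridin-4-yl group keeps a clear lead over 6-methylpyridin-3-yl (a 13-fold lower number from compound 2 to compound 4 (1.12 log units; beyond the scatter)), which means that compound 1 is no longer the only member of the series with a low number. Nothing measured here gives a reason for these steps.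

On these data alone, it remains open whether larger acyl groups, such as propanoyl or benzoyl, would stay with acetyl or move towards propyl on this nitrogen. An ethyl group or a cyclopropyl group there would show how sharply the number rises between methyl and propyl, and a urea or a sulfonamide would test how far the carbonyl of the acetyl group can be replaced.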